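The source may report more compounds than this note shows. Statements on the series, on what has been measured and on what is new or still open speak of the compounds shown alone.

Three compounds have been measured in a physicochemical assay for lipophilicity; on this read-out higher numbers stand for higher lipophilicity and lower numbers for lower lipophilicity:

compound 1 `Cc1cc(C#N)cc(C)c1Oc1ccnc(Nc2ccc(C#N)cc2)n1` gives 1.39
compound 2 `Cc1cc(C)c(Oc2ccnc(Nc3ccc(C#N)cc3)n2)c(C)c1` gives 1.82
compound 3 `Cc1cc(C#N)cc(C)c1Nc1nc(Nc2ccc(C#N)cc2)ncc1C#N` gives 1.06

In this assay compound 3 gives the lowest of the three numbers; compound 1 stands nearest to it and compound 2 furthest, both gaps beyond the usual scatter. Compound 1 and compound 2 differ in one place:

methyl in place of cyano on an aromatic carbon

This change carried the step of a number 0.43 log units higher from compound 1 to compound 2 (beyond the scatter), a modest rise beyond the scatter.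

Compound 4 `Cc1cc(C)c(Nc2nc(Nc3ccc(C#N)cc3)ncc2C#N)c(C)c1` has not yet been measured. It differs from compound 3 in one place:

methyl in place of cyano on an aromatic carbon

Within the data shown here, the two surroundings are the same word for word, so this is the same change as the one from compound 1 to compound 2. The cores of compound 1 and compound 3 differ in more than one place, and that difference is not broken down here.

Resting on the measured step of a number 0.43 log units higher from compound 1 to compound 2 (beyond the scatter), the step from compound 3 to compound 4 is expected to be a number 0.43 log units higher from compound 3 to compound 4 (beyond the scatter). Compound 4 is therefore estimated at 1.49, most likely between 1.15 and 1.85.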

Compound 4, partition coefficient: 1.49
Beside the measured number, compound 4's estimate shows no gap at the digits printed, within the range that was stated.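

In this assay, methyl in place of cyano on an aromatic carbon gave a step of a number 0.43 log units higher from compound 3 to compound 4 (beyond the scatter), and on the other core the same change gave a step of a number 0.43 log units higher from compound 1 to compound 2 (beyond the scatter), so the two steps agree at the digits printed and the change carried over between these two cores. Among these compounds, this rests on only one pair of compounds for each core, so it does not show that the step would hold on any further core, and the cores of compound 1 and compound 3 differ in more than one place, so it cannot be said which of those differences, if any, would matter for the transfer. Nothing measured here bears on why the step has this size.

Among the compounds shown, this aromatic carbon carries only cyano or methyl. As far as these compounds go, how an amine, a carboxylic acid or a longer chain such as propyl on that carbon would read on either core remains open.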